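A few compounds are considered here, and "the series" means these few. Any claim that something is new, unique, unknown or untested is made for them only; others in the source may bear on it.

Of the compounds shown here, two have numbers so far. In a functional assay on DU-145 cells (Homo sapiens) for cytotoxicity, read by MTT assay, with a stated time of 48 h (a higher number here means a weaker inhibitor, a lower number a stronger inhibitor), compound 1 (`COc1ccc(-c2nc3ccccn3c2C(=O)/C=C\Nc2ccc3[nH]ccc3c2)cc1`) gives 11300 nM and compound 2 (`COc1cc(N/C=C\C(=O)c2c(-c3ccc(Cl)cc3)nc3ccccn23)cc(OC)c1`) gives 12000 nM. Compound 2 therefore stands level with compound 1, the two values lying within the scatter of each other. Still unmeasured is compound 3 (`O=C(/C=C\Nc1ccc2[nH]ccc2c1)c1c(-c2ccc(Cl)cc2)nc2ccccn12`), which differs from compound 2 in one place: 1H-indol-5-yl in place of 3,5-dimethoxyphenyl on an amine nitrogen. In words, 1H-indol-5-yl takes the place of 3,5-dimethoxyphenyl on an amine nitrogen. Within the data shown here, no measured pair isolates a single change, and the data hold no direct step for this swap. Among the measured compounds shown here, the only pointer is compound 1, which also carries 1H-indol-5-yl on an amine nitrogen and gives 11300 nM in this assay, level with compound 2. No shift beyond the scatter is expected in either direction, and the estimated change is a 1.1-fold lower number from compound 2 to compound 3 (0.04 log units; within the scatter). For compound 3 the expected value is 11000 nM, with an estimated range of 4500 nM to 25000 nM.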

Compound 3, half-maximal inhibitory concentration: 1290 nM
Beside the measured number, compound 3's estimate is 8.5-fold (0.93 log units) above it; measured number below the stated range.
By their numbers in this assay, from the lowest: compound 3; then compounds 1 and 2 (each within the scatter of the next).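

Among these compounds, on an amine nitrogen, 1H-indol-5-yl in place of 3,5-dimethoxyphenyl gives a 9.3-fold lower number from compound 2 to compound 3 (0.97 log units; beyond the scatter) in this assay, the first step that isolates this swap, and it shows that the number responds to the group held at this position. Chloro in place of methoxy on an aromatic carbon gives an 8.8-fold lower number from compound 1 to compound 3 (0.94 log units; beyond the scatter), so a second place responds as well, and each step is read with the other group already present: the 1H-indol-5-yl step with chloro in place, the chloro step with 1H-indol-5-yl in place. Nothing in hand bears on what lies behind either step.

The compounds shown leave open whether the swap on the amine nitrogen gives a step of similar size with methoxy on the aromatic carbon, and whether chloro gives one with 3,5-dimethoxyphenyl on the amine nitrogen. Also open, going by these compounds, is whether a bromo or trifluoromethyl group on the aromatic carbon, or 1-methyl-1H-indol-5-yl on the amine nitrogen, would keep the lower number of compound 3.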